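The source may report more compounds than this note shows. Statements on the series, on what has been measured and on what is new or still open speak of the compounds shown alone.

Compound 2 `COc1ccccc1-n1nc(C2CC(C)(C)OC(C)(C)C2)cc1-c1ccc(Cl)cc1` gives 16 nM in an assay on HEK293 cells for inhibition of Voltage-dependent N-type calcium channel subunit alpha-1B (Homo sapiens), read by patch clamp, using a membrane potential dye; a higher number here means a weaker inhibitor, a lower number a stronger inhibitor. Among the three compounds measured it stands second highest: its nearest neighbour is compound 1 `COc1ccccc1-n1nc([C@H]2C[C@@H](C)O[C@@H](C)C2)cc1-c1ccc(Cl)cc1`, which gives 12 nM, a change of a 1.3-fold higher number from compound 1 to compound 2 (0.12 log units; within the scatter); its furthest is compound 3 `CC1(C)CC(c2cc(-c3ccc(Cl)cc3)n(-c3ccncc3)n2)CC(C)(C)O1`, which gives 22000 nM, a change of a 1400-fold higher number from compound 2 to compound 3 (3.14 log units; beyond the scatter). Compound 4 `COc1ccccc1-n1nc(C2CC(C)(C)OC(C)(C)C2)cc1-c1csc(Cl)c1` differs from compound 2 by 5-chlorothiophen-3-yl in place of 4-chlorophenyl on an aromatic carbon. For the measured compounds named here, neither measured step touches this group: one alters the oxane substituent, the other the group on the ring nitrogen, so no direct precedent exists. A modest step, likely within the scatter, is expected for a 1.9-fold higher number from compound 2 to compound 4 (0.27 log units; within the scatter). Compound 4 is therefore estimated at 30 nM, with a range from 8 nM to 120 nM.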

Compound 4, half-maximal inhibitory concentration: 28 nM
For compound 4 the middle estimate is 1.1-fold (0.03 log units) above the measured one; low and high end bracket the measured number.
By their numbers in this assay, from the lowest: compounds 1, 2 and 4 (each within the scatter of the next, the first and the last beyond it); then compound 3.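

For the compounds shown here, the first change at this position, the aromatic carbon next to the ring nitrogen, puts 5-chlorothiophen-3-yl in place of 4-chlorophenyl and gives a 1.8-fold higher number from compound 2 to compound 4 (0.24 log units; within the scatter). A five-membered aromatic ring with a sulfur therefore serves here as well as the six-membered carbon ring, unlike the change on the ring nitrogen, which gave a 1400-fold higher number from compound 2 to compound 3 (3.14 log units; beyond the scatter). No measurement here offers a reason for this result. As far as these compounds go, what the chlorine itself contributes stays open, as does whether a nitrile or an amine in its place would hold the number of compound 2.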